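The compounds below may be only part of what the source reports. "The series", "measured", "known", "first", "only" and "open" are said of these compounds alone.

Three ureas built on the shared core have been measured in a functional assay on WiDr cells (Homo sapiens) for inhibition (on this read-out lower numbers stand for stronger inhibition and higher numbers for weaker inhibition), so far. Compound 1 `CCOC(=O)CNC(=O)N1CC1C#N` gives 33000 nM in this assay, and compound 2 `CCCCNC(=O)N1CC1C#N` gives 18000 nM. Compound 3 `N#CC1CN1C(=O)Nc1ccc(F)cc1` gives 9000 nM, the smallest of the three numbers: its gap to compound 2 lies within the scatter, while its gap to compound 1 lies beyond it. The two alkyl-substituted ureas and the one aryl-substituted urea thus span a narrow range, with the aryl case at the low end.

Compound 4 `CCOC(=O)c1ccc(NC(=O)N2CC2C#N)cc1` is not yet measured. It differs from compound 3 by ethoxycarbonyl in place of fluoro on an aromatic carbon. Going by the values given here, no measured pair isolates this change, so the direction and size of the step rest on the structural change alone. The aryl urea of compound 3 already holds the lowest number, and the added group is expected to be tolerated on the aromatic carbon; a modest step downward, a 1.8-fold lower number from compound 3 to compound 4 (0.26 log units; within the scatter), is expected, but one that may well fall within the scatter. Compound 4 is estimated at 5000 nM in this assay, within a range of 1500 nM to 18000 nM.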

Compound 4, half-maximal inhibitory concentration: 4200 nM
For compound 4 the middle estimate is 1.2-fold (0.08 log units) above the measured one, and the stated range covers the measured number.
By their numbers in this assay, from the lowest: compound 4; then compounds 3, 2 and 1 (each within the scatter of the next, the first and the last beyond it).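

In this assay, going by these compounds alone, ethoxycarbonyl in place of fluoro gives a 2.1-fold lower number from compound 3 to compound 4 (0.33 log units; beyond the scatter), the first single-place comparison and one that lies just beyond the scatter. The aromatic carbon para to a group of 8 heavy atoms therefore accepts a group of 5 heavy atoms with 2 hydrogen-bond acceptors in place of a single fluorine, with no loss in this read-out and a modest move to a lower number. No available data bear on what lies behind this step.

As far as these compounds go, it remains open whether the step belongs to the ester itself or would also appear with other groups on this carbon, such as a carboxylic acid or a primary amide. A longer ester, such as butoxycarbonyl, would show whether the direction continues with chain length.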